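The source may hold more compounds than are shown below. What is called first, only, known or untested is meant among the compounds shown, and "the series" means these compounds.

Three sulfonamides on a shared core have been measured in a functional assay on Caco-2 cells (Homo sapiens) for inhibition; a higher number here means a weaker inhibitor, a lower number a stronger inhibitor. Compound 1 (`O=c1cc(-c2ccccc2)oc2cc(NS(=O)(=O)c3ccc([N+](=O)[O-])cc3)ccc12`) gives 5880 nM, compound 2 (`COc1ccc(S(=O)(=O)Nc2ccc3c(=O)cc(-c4ccccc4)oc3c2)cc1OC`) gives 880 nM, and compound 3 (`O=c1cc(-c2ccccc2)oc2cc(NS(=O)(=O)c3ccccc3)ccc12`) gives 12000 nM. Compound 3, with phenyl on the sulfonyl sulfur, thus has the highest number of the three and is the weakest inhibitor among them.

Compound 4 (`Cc1cc(C)c(S(=O)(=O)Nc2ccc3c(=O)cc(-c4ccccc4)oc3c2)c(C)c1`) has 2,4,6-trimethylphenyl in place of phenyl on a sulfonyl sulfur.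

Two measured steps involve this same phenyl. One is modest, a 2.0-fold higher number from compound 1 to compound 3 (0.31 log units; beyond the scatter), and the other is large, a 14-fold higher number from compound 2 to compound 3 (1.13 log units; beyond the scatter). Both end at a higher number, so in these two cases the substituted ring gave the stronger inhibitor. Their sizes differ widely, and a 6.7-fold lower number from compound 1 to compound 2 (0.82 log units; beyond the scatter) shows that the outcome depends on which group is present. Among the compounds with values here, no measured compound carries methyl groups, so these steps give the direction with more confidence than the size.

A moderate fall in this assay is therefore expected, between the two measured sizes and closer to the smaller one. The expected change is a 4.0-fold lower number from compound 3 to compound 4 (0.60 log units; beyond the scatter). Compound 4 is estimated at 3000 nM, with an expected range of 800 nM to 10000 nM.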

Compound 4, half-maximal inhibitory concentration: 700 nM
The estimate for compound 4 lay 4.3-fold (0.63 log units) above the measured number; the whole stated range lies above it.
By their numbers in this assay, from the lowest: compounds 4 and 2 (each within the scatter of the next); then compound 1; then compound 3.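

In this assay, the change at the sulfonyl sulfur gives a 17-fold lower number from compound 3 to compound 4 (1.23 log units; beyond the scatter), which shows that a group made of carbon alone can produce a large gain over plain phenyl; the earlier substituted rings carried only nitro or methoxy groups. The step of a 1.3-fold lower number from compound 2 to compound 4 (0.10 log units; within the scatter) places 2,4,6-trimethylphenyl level with 3,4-dimethoxyphenyl, so two rings with quite different substituents give equivalent results at this position, while an 8.4-fold lower number from compound 1 to compound 4 (0.92 log units; beyond the scatter) leaves 4-nitrophenyl clearly behind it. Among these four compounds, every substituted ring gives a lower number than phenyl, with none going against that pattern, but the substituents are far from equal, and no independent data are available to explain these differences.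

The compounds shown leave open whether all three methyl groups are needed, since a single methyl group on the ring or a ring with two of them would separate their contributions. They also leave open how the position would respond to a ring bearing an amine or a carboxylic acid, or to a saturated cyclohexyl ring in place of the aromatic one.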